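A few compounds are considered here, and "the series" means these few. Any claim that something is new, unique, unknown or untested is made for them only; others in the source may bear on it.

In a functional assay on MT4 cells (Homo sapiens) for cytotoxicity, read by MTT assay (on this read-out higher numbers stand for lower toxicity in this test and lower numbers for higher toxicity in this test), three compounds built on a shared core have been tested so far, and none of them gave an exact number. Compound 1 `COc1ccc(CSc2nc(O)c(C)c(Cc3c(F)cccc3F)n2)cc1` gives > 64000 nM, which is a limit. Compound 2 `Cc1c(O)nc(SCc2ccc([N+](=O)[O-])cc2)nc1Cc1c(Cl)cccc1Cl` gives > 58000 nM, which is also a limit. Compound 3 `Cc1c(O)nc(SCc2ccc([N+](=O)[O-])cc2)nc1Cc1ccc(F)cc1` gives > 65000 nM, again a limit, so it sits with the other two and cannot be ranked against them.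

Compound 4 `COc1ccc(CSc2nc(O)c(C)c(Cc3ccc(F)cc3)n2)cc1` differs from compound 3 by having methoxy in place of nitro on an aromatic carbon, para to a large group: methoxy in place of nitro on an aromatic carbon. Within the data shown here, the only measured step is a step that the two limits leave unreadable from compound 2 to compound 3. It changes another part of the molecule and has no readable size, so it offers nothing to carry over. The nearest guide is compound 1, which also carries the 4-methoxyphenyl group and shows > 64000 nM, a limit. The expected change, a step that the limit leaves unreadable from compound 3 to compound 4, is therefore none beyond the usual scatter, in either direction. Compound 4 is estimated at 67000 nM, with an expected range from 30000 nM to 100000 nM, and will probably be reported only as a limit.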

Compound 4, half-maximal cytotoxic concentration: 8900 nM
The estimate for compound 4 lay 7.5-fold (0.88 log units) above the measured number; measured number outside the range, below it.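

In this assay, the exchange on the aromatic ring can clearly matter: with the 4-fluorophenyl group kept, methoxy in place of nitro gives an at least 7.3-fold lower number from compound 3 to compound 4 (0.86 log units; beyond the scatter), meaning higher toxicity in this test. The 4-methoxyphenyl group is not enough by itself, since moving from the 2,6-difluorophenyl to the 4-fluorophenyl group with the methoxy kept gives an at least 7.1-fold lower number from compound 1 to compound 4 (0.85 log units; beyond the scatter), so among these compounds the lower number appears only where 4-methoxyphenyl and 4-fluorophenyl occur together. The step from nitro to methoxy is only a minimum size because compound 3 stands at a limit: the limit of > 65000 nM in this assay, at which 1 of the 4 values shown sits.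

Going by these compounds, it remains open whether an amino or hydroxyl group in the same place would give a similarly low number. On these data alone, it is also open whether a longer alkoxy chain, such as ethoxy, would do so.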